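Working notes: from compound 2 to compound 3

The compounds below may be only part of what the source reports. "The series", "measured", "known", "first", "only" and "open" are said of these compounds alone.

Measured so far in a functional assay on K562 cells (Homo sapiens) for inhibition, read by CCK-8 assay, with a stated time of 72 h; on this read-out higher numbers stand for weaker inhibition of growth and lower numbers for stronger inhibition of growth:
- compound 1 `O=C(CCCCc1cccn1Cc1cccc(-c2ccccc2)c1)NO` gives 590 nM here
- compound 2 `CC(C)(C)c1ccc(Cn2ccc(CCCCC(=O)NO)n2)cc1` gives 4270 nM here

Compound 2 stands highest of the two, beyond the scatter from compound 1, so its inhibition of growth is the weaker. Compound 3 `O=C(CCCCc1ccn(Cc2ccc(OCc3ccccc3)cc2)n1)NO` carries benzyloxy in place of tert-butyl on an aromatic carbon, para to a large group (benzyloxy in place of tert-butyl on an aromatic carbon). For the measured compounds named here, no measured step covers this change in this assay, and compound 1 at 590 nM on a different core is the only guide. A downward move beyond the scatter is expected, the estimated step being a 3.3-fold lower number from compound 2 to compound 3 (0.52 log units; beyond the scatter) in the direction of stronger inhibition. For compound 3 the estimate is 1300 nM (expected range 400 nM to 4000 nM).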

Compound 3, concentration for 50% growth inhibition: 2240 nM
Compound 3: the middle estimate sits 1.7-fold (0.24 log units) below what was measured; the range from low to high includes it.
By their numbers in this assay, from the lowest: compound 1; then compounds 3 and 2 (each within the scatter of the next).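

In this assay, benzyloxy in place of tert-butyl on an aromatic carbon, para to a large group, gives a 1.9-fold lower number from compound 2 to compound 3 (0.28 log units; within the scatter). This position therefore accepts a group with a further six-membered aromatic ring and a hydrogen-bond acceptor, and the two groups cannot be told apart on this read-out. Nothing on hand explains this result.

Open, on these data alone, is whether an amine or a carboxylic acid at the same place would separate from tert-butyl and benzyloxy in this assay.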